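The source may report more compounds than this note shows. Statements on the series, on what has been measured and on what is new or still open speak of the compounds shown alone.

Compound 1, `COc1cc2c(cc1O)CCC(C)(CC(=O)O)O2`: 100%
Compound 2, `COc1cc2c(cc1O)CCC(C)(CC(N)=O)O2`: 100%
Compound 3, `COc1cc2c(cc1O)CCC(C)(CCNC(C)=O)O2`: 87.8%

All three numbers come from an ADME assay on SH-SY5Y cells (Homo sapiens) for cytotoxicity, read by MTT assay, with a stated time of 24 h, tested at 6.3 uM; on this read-out higher numbers stand for a weaker effect at the one concentration tested and lower numbers for a stronger effect. Compound 3 stands lowest of the three, which on this read-out means the strongest effect at the one concentration tested: a number 12.2 percentage points lower from compound 1 to compound 3 (beyond the scatter), and a number 12.2 percentage points lower from compound 2 to compound 3 (beyond the scatter). By contrast, no change at the digits printed from compound 1 to compound 2 (within the scatter), so exchanging the carboxy for a carbamoyl on the shared core made no difference that can be trusted.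

The next compound, compound 4, `COc1cc2c(cc1O)CCC(C)(CC(N)C(=O)O)O2`, has not yet been measured. It differs from compound 3 in one place: amino(carboxy)methyl in place of acetamidomethyl on a saturated chain carbon bound to a saturated ring carbon. The two steps that bear on this change are the ones leading into compound 3, where replacing a carboxy or a carbamoyl with acetamidomethyl lowered the number by a modest amount. Compound 4 brings a carboxy back into the group at that place, together with an amino, so the expectation is that the number moves back toward the values of compound 1 and compound 2, by a step of about a number 7.2 percentage points higher from compound 3 to compound 4 (within the scatter), which may or may not exceed the scatter. Compound 4 is therefore estimated at 95%, with a range from 82% to 105%.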

Compound 4, a percentage reported as activity, at one concentration (the size of the read-out at that concentration, not a potency): 100%
Estimate against measurement, compound 4: 5 percentage points below; the measured number falls inside the stated range.
By their numbers in this assay, from the lowest: compound 3; then compounds 1, 2 and 4 (each within the scatter of the next).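

In this assay, amino(carboxy)methyl in place of acetamidomethyl on a saturated chain carbon bound to a saturated ring carbon gives a number 12.2 percentage points higher from compound 3 to compound 4 (beyond the scatter), so the lower number at this place does not hold for every group with the same heavy-atom count as acetamidomethyl. The new group also shows no change at the digits printed from compound 2 to compound 4 (within the scatter) and no change at the digits printed from compound 1 to compound 4 (within the scatter), which leaves compound 3 as the only one of the four set apart, while three different groups at this place cannot be told apart in this read-out. Nothing measured here gives a reason for this difference.

The compounds shown leave open whether the lower number goes with the acetyl part of compound 3, so a plain primary amine on the same chain, or an acetamido group on a chain that also carries a carboxylic acid, would separate those possibilities. They also say nothing about a longer chain at this place, or about how any of these compounds behave away from the one concentration tested.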